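A second chloro in a series resting at its limit

The compounds below may be only part of what the source reports. "The series", "measured", "known", "first", "only" and "open" are said of these compounds alone.

Compound 1 `CCOC(=O)c1c(-c2cccc(-c3ccccc3)c2)[nH]c2cc(OC)ccc2c1=O` opens this short series, and in an ADME assay on Raji cells (Homo sapiens) for cytotoxicity, read by luminescence, with a stated time of 72 h (on this read-out lower numbers stand for an effect already at smaller amounts and higher numbers for an effect only at larger amounts of compound), compound 1 reads > 21500 nM, which is a limit and not a number. Compound 2 `CCOC(=O)c1c(-c2cccc(-c3ccccc3)c2)[nH]c2cc(OC(C)C)ccc2c1=O`, with isopropoxy in place of methoxy, reads > 21500 nM, again a limit. Compound 3 `CCOC(=O)c1c(-c2cccc(-c3ccccc3)c2)[nH]c2cc(Cl)ccc2c1=O`, with chloro in place of methoxy, reads > 21500 nM, also a limit. Compound 3 therefore has no number of its own, and what the three share is the limit of > 21500 nM in this assay, at which 3 of the 3 values shown sit.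

Compound 4 `CCOC(=O)c1c(-c2cccc(-c3ccccc3)c2)[nH]c2cc(Cl)c(Cl)cc2c1=O` keeps that chloro and gains a second one: chloro in place of hydrogen on an aromatic carbon. The measured changes offer no size to lean on. Isopropyl for methyl is a step that the two limits leave unreadable from compound 1 to compound 2, chloro for methoxy is a step that the two limits leave unreadable from compound 1 to compound 3, and chloro for isopropoxy is a step that the two limits leave unreadable from compound 2 to compound 3. None adds a second chloro, so no firm size or direction can be expected. The expected result is an at least 1.0-fold lower number from compound 3 to compound 4 (0.03 log units; that floor lies within the scatter), quite probably another limit. For compound 4 the estimated value is 20000 nM, with an expected range from 7000 nM to 30000 nM.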

Compound 4, half-maximal effective concentration: > 21500 nM
Compound 4 was reported as a limit; the forecaster's own chance of this, stated with the estimate: 75%; middle value at least 1.0-fold (0.03 log units) away from the limit.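

Compound 4 gives no readable step from compound 3, and the second chloro has no size that can be stated, because both results are limits and not numbers: the limit of > 21500 nM in this assay, at which 4 of the 4 values shown sit.

The compounds shown leave open whether any change to the shared core would give an actual number in this assay.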